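Phenoxycarbonyl on the amine of a triarylethylene

The source may report more compounds than this note shows. Statements on the series, on what has been measured and on what is new or still open speak of the compounds shown alone.

Compound 1 `COc1ccc(/C(=C(/CCN=[N+]=[N-])c2ccccc2)c2ccccc2)cc1`: "not active" (no number reported)
Compound 2 `COc1ccc(/C(=C(/CCN)c2ccccc2)c2ccccc2)cc1`: 16900 nM

Within the data shown here, in a functional assay on MCF7 cells (Homo sapiens) for cytotoxicity, read by MTT assay, with a stated time of 72 h (a higher number here means a weaker inhibitor, a lower number a stronger inhibitor), compound 2 gives 16900 nM, the only number in the set; compound 1 is reported in this assay as "not active" (no number reported) without a number. Compound 3 `COc1ccc(/C(=C(/CCNC(=O)Oc2ccccc2)c2ccccc2)c2ccccc2)cc1` differs from compound 2 by phenoxycarbonyl in place of hydrogen on an amine nitrogen. Among the measured compounds shown here, no measured pair shows what this change does. A moderate shift toward stronger inhibition is expected, beyond the scatter, though a reported limit cannot be excluded. The step from compound 2 to compound 3 is estimated at a 2.1-fold lower number from compound 2 to compound 3 (0.32 log units; beyond the scatter). Compound 3 is expected near 8000 nM, within 2500 nM to 25000 nM.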

Compound 3, half-maximal inhibitory concentration: "not active" (no number reported)
For compound 3 the study gives words and no number, so the estimate cannot be set against anything.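

In this assay, among these compounds, compound 3 has no number, so no step from compound 2 to compound 3 can be read. The compounds shown leave open what phenoxycarbonyl on the amine nitrogen does to the number, and no evidence shown bears on this result.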